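A Second Methyl Group and Cytotoxicity in Cells

The source may hold more compounds than are shown below. What is called first, only, known or untested is meant among the compounds shown, and "the series" means these compounds.

Compound 1 `CNC(=O)c1cc(Oc2ccc(-c3noc(C4CC4)n3)cc2)ccn1`: 32300 nM
Compound 2 `CNC(=O)c1cc(Oc2ccc(-c3noc(C4CC4)n3)cc2C)ccn1`: 20000 nM
Compound 3 `CNC(=O)c1cc(Oc2ccc(-c3noc(C(C)C)n3)cc2C)ccn1`: 8900 nM

All three were tested in an ADME assay on H1-HeLa cells (Homo sapiens) for cytotoxicity, read by MTT assay, with a stated time of 3 days; on this read-out lower numbers stand for higher toxicity in this test and higher numbers for lower toxicity in this test. Compound 2 differs from compound 1 by methyl in place of hydrogen on an aromatic carbon, which gave a 1.6-fold lower number from compound 1 to compound 2 (0.21 log units; within the scatter). Compound 3 then gave a 2.2-fold lower number from compound 2 to compound 3 (0.35 log units; beyond the scatter). Compound 4 `CNC(=O)c1cc(Oc2c(C)cc(-c3noc(C(C)C)n3)cc2C)ccn1` is not yet measured; it differs from compound 3 by methyl in place of hydrogen on an aromatic carbon. This is the same kind of change as from compound 1 to compound 2, not the same one: in compound 4 the new methyl sits meta to a methyl group and meta to a 5-isopropyl-1,2,4-oxadiazol-3-yl group, where the earlier methyl sat meta to a 5-cyclopropyl-1,2,4-oxadiazol-3-yl group. The difference between the cores of compound 1 and compound 3 is not broken down here. Because the earlier step of a 1.6-fold lower number from compound 1 to compound 2 (0.21 log units; within the scatter) was small, a similar step a 1.5-fold lower number from compound 3 to compound 4 (0.17 log units; within the scatter) is expected in this assay. Compound 4 is therefore estimated at 6000 nM, most likely between 2500 nM and 15000 nM.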

Compound 4, half-maximal cytotoxic concentration: 7400 nM
For compound 4 the middle estimate is 1.2-fold (0.09 log units) below the measured one; the range from low to high includes it.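

In this assay the second methyl group gave a 1.2-fold lower number from compound 3 to compound 4 (0.08 log units; within the scatter) on the core of compound 3. Set beside the earlier step, the same change looks alike on the two cores: the same change on two cores in this assay, a 1.6-fold lower number (0.21 log units; within the scatter) from compound 1 to compound 2 and a 1.2-fold lower number (0.08 log units; within the scatter) from compound 3 to compound 4, 1.3-fold (0.13 log units) apart, within the scatter of two such steps

This shows only that methyl in place of hydrogen made a small step each time, and neither step lies beyond the scatter, so no real effect of the methyl on toxicity in this test is shown, and two cores cannot show how the change behaves on any other core.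

The compounds shown leave open whether another group on this aromatic carbon, such as a chlorine atom, a methoxy group or an amine, would move the number beyond the scatter.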